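This account rests on a few compounds, and the source may have more. Where it says the series, first, only, none or still open, it means among the compounds named here.

Measured compounds:
compound 1 `CC(C)N1CCc2nc(C#Cc3cccc(Cl)c3)ccc2C1=O` 100 nM
compound 2 `CC(C)N1CCc2nc(C#Cc3ccccn3)ccc2C1=O` 2740 nM

Among the compounds with values here, in an assay on HEK293 cells for displacement of a labelled ligand from metabotropic glutamate receptor 5 (Homo sapiens), with a stated time of 2 h (on this read-out higher numbers stand for weaker inhibition and lower numbers for stronger inhibition), compound 2 gives the highest of the two numbers, with compound 1 at 100 nM as its only neighbour, a gap of a 27-fold higher number from compound 1 to compound 2 (1.44 log units; beyond the scatter). Compound 3 `CC(C)N1CCc2nc(C#Cc3cccnc3)ccc2C1=O` differs from compound 2 by pyridin-3-yl in place of pyridin-2-yl on a triple-bonded carbon. Within the data shown here, no measured step covers this change; the step from compound 1 to compound 2 concerns a different ring and only shows that the group on the triple bond can move the number a great deal. Compound 3 is therefore expected to move by a 6.9-fold lower number from compound 2 to compound 3 (0.84 log units; beyond the scatter), with much uncertainty. The estimate for compound 3 is 400 nM, within 70 nM to 2500 nM.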

Compound 3, inhibition constant: 19600 nM
Compound 3: the middle estimate sits 49-fold (1.69 log units) below what was measured; the whole stated range lies below it.
By their numbers in this assay, from the lowest: compound 1; then compound 2; then compound 3.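

Swapping pyridin-2-yl for pyridin-3-yl keeps the same atoms yet gives a 7.2-fold higher number from compound 2 to compound 3 (0.85 log units; beyond the scatter) in this pair, so on the triple-bonded carbon the way the ring is joined counts, not only which ring is there. Against the 3-chlorophenyl group, pyridin-3-yl gives a 200-fold higher number from compound 1 to compound 3 (2.29 log units; beyond the scatter) and leaves compound 3 with the weakest inhibition of the three. Nothing available explains why these changes have this effect. Still open, on these data alone, is how a plain phenyl, a 3-methylphenyl or a pyridin-4-yl group would behave at this position.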